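Working notes: methoxy to allyloxy in compound 2

The compounds below may be only part of what the source reports. "The series", "measured", "known", "first", "only" and "open" are said of these compounds alone.

Measured in a functional assay on HepG2 cells (Homo sapiens) for antiproliferative activity, read by MTT assay, with a stated time of 24 h (a higher number here means a weaker inhibitor, a lower number a stronger inhibitor), so far
Compound 1 `C=CCc1cc(-c2cccc(C(F)(F)F)c2)ccc1O` gives 58300 nM
Compound 2 `C=CCc1cc(-c2cccc([N+](=O)[O-])c2)ccc1OC` gives > 100000 nM as a limit of the assay
Compound 3 `C=CCc1cc(-c2ccc(NC(C)=O)cc2)ccc1OC` gives 60100 nM

Compound 2 stands at the limit of > 100000 nM in this assay, at which 1 of the 3 values shown sits, and has no number of its own. For the measured compounds named here, compound 1 and compound 3 carry numbers within the scatter of each other, and no measured pair differs in one place only.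

Compound 4 `C=CCOc1ccc(-c2cccc([N+](=O)[O-])c2)cc1CC=C` is compound 2 changed in one place: vinyl in place of hydrogen on a saturated chain carbon bound to an oxygen on an aromatic ring (vinyl in place of hydrogen on a saturated chain carbon bound to an oxygen on an aromatic ring, so methoxy becomes allyloxy). Going by these compounds, no measured step sizes this change, so no step beyond the scatter is expected in this assay and the direction stays open. The expected step is an at least 1.1-fold lower number from compound 2 to compound 4 (0.04 log units; that floor lies within the scatter) and it remains only an estimate. The assay may again report only a limit for compound 4. The estimate for compound 4 is 90000 nM (expected range 40000 nM to 200000 nM).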

Compound 4, half-maximal inhibitory concentration: > 100000 nM
Compound 4 gave a limit, no number (the forecaster's own chance of this, stated with the estimate: 50%); at least 1.1-fold (0.04 log units) between middle value and limit.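

For the compounds shown here, compound 4 returns only a limit in this assay, as compound 2 does, so no step between the two can be read: the limit of > 100000 nM in this assay, at which 2 of the 4 values shown sit. The compounds shown leave open whether allyloxy in place of methoxy changes antiproliferative potency at all on this core.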